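The source may report more compounds than this note shows. Statements on the series, on what has been measured and on what is new or still open speak of the compounds shown alone.

In a functional assay on K562 cells (Homo sapiens) for cytotoxicity, read by trypan blue exclusion, with a stated time of 96 h (on this read-out lower numbers stand for stronger inhibition and higher numbers for weaker inhibition), compound 1 (`O=S(=O)(/C=C/c1ccccc1)Nc1ccccc1`) gives 10000 nM. Compound 2 (`COc1cc(OC)c(/C=C/S(=O)(=O)Nc2cc([N+](=O)[O-])c(OC)c([N+](=O)[O-])c2)c(OC)c1`) gives 10000 nM, so the two stand level on the numbers shown. Compound 3 (`O=S(=O)(/C=C/c1ccccc1)Nc1ccc(Cl)cc1`) differs from compound 1 in one place: chloro in place of hydrogen on an aromatic carbon, with chloro in place of hydrogen on an aromatic carbon, para to a large group. Going by the values given here, no measured pair shows what a single change like this does, so only a small shift toward stronger inhibition is expected, not clearly beyond the scatter. The expected step is a 1.7-fold lower number from compound 1 to compound 3 (0.22 log units; within the scatter). For compound 3 the estimate is 6000 nM, with an expected range of 1500 nM to 15000 nM.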

Compound 3, half-maximal inhibitory concentration: 20000 nM
Compound 3: the middle estimate sits 3.3-fold (0.52 log units) below what was measured; the measured number lies above the stated range.
By their numbers in this assay, from the lowest: compounds 1, 2 and 3 (each within the scatter of the next).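

Chloro in place of hydrogen on an aromatic carbon, para to a large group, gives a 2.0-fold higher number from compound 1 to compound 3 (0.30 log units; within the scatter) in this assay. This first single-place comparison shows that, at this position, chloro does not separate compound 3 from compound 1 beyond the usual scatter, so it brings no clear gain in inhibition. No measurement shown here offers an explanation for this result. On these data alone, whether an amine or a carboxylic acid at this same position would behave like chloro remains open, as does the effect of chloro on another carbon of this ring.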